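The source may hold more compounds than are shown below. What is called first, only, known or untested is meant among the compounds shown, and "the series" means these compounds.

Measured compounds:
- compound 1, `CN(C(=O)NC(=O)c1cccc(C(F)(F)F)c1)c1nc(C(F)(F)F)c(C(=O)N/N=C/c2ccc(C(F)(F)F)cc2)s1`: in a functional assay on HepG2 cells (Homo sapiens) for inhibition, read by MTT assay, with a stated time of 72 h (a lower number here means a stronger inhibitor, a higher number a weaker inhibitor), compound 1 gives 7.71 ug/mL
- compound 2, `CN(C(=O)NC(=O)c1cccc(C(F)(F)F)c1)c1nc(C(F)(F)F)c(C(=O)N/N=C/c2ccccc2C(F)(F)F)s1`: compound 2 gives 10.4 ug/mL
- compound 3, `CN(C(=O)NC(=O)c1ccccc1F)c1nc(C(F)(F)F)c(C(=O)N/N=C/c2cccc(C(F)(F)F)c2)s1`: compound 3 gives 20.3 ug/mL

Compound 2 stands second highest of the three numbers; its nearest neighbour is compound 1, its furthest compound 3, and both of those gaps fall within the scatter. For the measured compounds named here, the one step recorded, a 1.3-fold higher number from compound 1 to compound 2 (0.13 log units; within the scatter), concerns the aryl group on the carbon with a double bond to nitrogen and is itself within the scatter. Going by the values given here, compound 3 differs from compound 2 in two places at once, so its value alone shows nothing about the single change considered here.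

Compound 4, `CN(C(=O)NC(=O)c1cccc([N+](=O)[O-])c1)c1nc(C(F)(F)F)c(C(=O)N/N=C/c2ccccc2C(F)(F)F)s1`, keeps the hydrazone part of compound 2 and differs on the acyl side: nitro in place of trifluoromethyl on an aromatic carbon. Among the compounds with values here, no measured step touches this position; all three numbers so far lie within the scatter of each other. The step of a 1.0-fold lower number from compound 2 to compound 4 (0.02 log units; within the scatter) is therefore expected to stay within the scatter, with no direction favoured. Compound 4 is estimated at 10 ug/mL, within a range of 4 ug/mL to 25 ug/mL.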

Compound 4, half-maximal inhibitory concentration: 4.8 ug/mL
Compound 4: middle estimate off by 2.1-fold (0.32 log units), on the high side; measured number inside the range.
By their numbers in this assay, from the lowest: compounds 4, 1, 2 and 3 (each within the scatter of the next, the first and the last beyond it).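

In this assay the aryl group on the acyl side can move the number: a 2.2-fold lower number from compound 2 to compound 4 (0.34 log units; beyond the scatter) is a modest step, but it lies beyond the scatter. The only earlier single-place step, a 1.3-fold higher number from compound 1 to compound 2 (0.13 log units; within the scatter), concerned the aryl group on the hydrazone side and stayed within the scatter, so this position is the one shown here to respond, with nitro in place of trifluoromethyl giving the lower number. Nothing available bears on why the number changes with this replacement.

Going by these compounds, it remains open whether the lower number is particular to nitro or would also appear with an amine, a carboxylic acid or a nitrile on this aromatic carbon. Also open, on these data alone, is whether the same replacement gives a step of similar size when the hydrazone side carries the 4-(trifluoromethyl)phenyl group of compound 1.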